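Swapping the Aryl Amide for a Small Polar Ring

This account rests on a few compounds, and the source may have more. Where it says the series, first, only, none or still open, it means among the compounds named here.

Compound 1 `Cc1cc(C)cc(NC(=O)COc2cc(C)nc3ccc(C(F)(F)F)cc23)c1`: 6.67
Compound 2 `COc1ccc2nc(C(F)(F)F)cc(OCC(=O)Nc3cc(C)cc(C)c3)c2c1`: 7.02
Compound 3 `COc1ccc(NC(=O)COc2cc(C)nc3ccc(OC)cc23)cc1`: 4.22

Of the compounds shown here, three have been measured in a physicochemical assay for lipophilicity, read by HPLC, in phosphate buffer, measured as chromatographic lipophilicity, at pH 7.4; a lower number here means a more polar compound, a higher number a more lipophilic compound. Compound 1 gives 6.67 and compound 2 gives 7.02, both well up the scale. Compound 3 stands lowest of the three, at 4.22; the nearest number, that of compound 1, is higher by a gap beyond the scatter, and the furthest, that of compound 2, is higher still, again beyond the scatter. No two of these three differ in only one place, so no single step can be read from them.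

Compound 4 `COc1ccc2nc(C)cc(OCC(=O)NC3CONC3=O)c2c1` shares the core of compound 3 and differs from it only at the amide nitrogen: a group of 6 heavy atoms (3 carbon, 1 nitrogen, 2 oxygen; one five-membered non-aromatic ring with 2 hetero atoms) in place of a group of 8 heavy atoms (7 carbon, 1 oxygen; one six-membered aromatic ring of carbon only), on an amide-type nitrogen. A large aromatic carbon group leaves and a small ring carrying a hydrogen-bond donor and two acceptors enters, so a large step downward in this assay is expected, far beyond the scatter. For compound 4 the expected value is 1.3, with a likely range from 0.3 to 2.3, which is an estimated step of a number 2.92 log units lower from compound 3 to compound 4 (beyond the scatter).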

Compound 4, distribution coefficient: 0.79
For compound 4 the middle estimate is 0.51 log units above the measured one; the range from low to high includes it.
By their numbers in this assay, from the lowest: compound 4; then compound 3; then compound 1; then compound 2.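

Among the compounds shown here, replacing the 4-methoxyphenyl on the amide-type nitrogen with the small five-membered ring gives, in this assay, a number 3.43 log units lower from compound 3 to compound 4 (beyond the scatter) as the first change in a single place that can be read. The earlier compounds shown here differed in more than one place, so only now can a large shift be tied to this one position, with the rest of the molecule held constant. Nothing measured here accounts for the size of this step.

Going by these compounds, the aromatic carbon ring leaves and a ring with hetero atoms enters in the same step, so the share of each in the change remains open. A cyclopentyl group or a plain phenyl group on the same amide-type nitrogen would help separate the two.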